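The source may report more compounds than this note shows. Statements on the series, on what has been measured and on what is new or still open speak of the compounds shown alone.

Working notes on the series in an ADME assay on MT4 cells (Homo sapiens) for cytotoxicity, read by MTT assay; on this read-out higher numbers stand for lower toxicity in this test and lower numbers for higher toxicity in this test.

Compound 1 `O=C(CSc1nncnc1-c1cccc2ccccc12)Nc1ccc([N+](=O)[O-])cc1Cl` gives 150000 nM in this assay. Among the three measured compounds it stands second highest: compound 2 `O=C(CSc1nncnc1-c1ccccc1Cl)Nc1ccccn1` gives 172000 nM, a value within the scatter of that of compound 1, while compound 3 `O=C(CSc1nncnc1-c1ccccc1Cl)c1ccc(Cl)c(Cl)c1` gives 33000 nM, which lies beyond the scatter below compound 1. Among the compounds with values here, the one single-point step measured so far is a 5.2-fold lower number from compound 2 to compound 3 (0.72 log units; beyond the scatter); it concerns the group on the carbonyl carbon, not the aryl on the amide-type nitrogen, so it does not bear directly on the change now considered.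

Compound 4 `Cc1ccc(NC(=O)CSc2nncnc2-c2cccc3ccccc23)c([N+](=O)[O-])c1` differs from compound 1 by 4-methyl-2-nitrophenyl in place of 2-chloro-4-nitrophenyl on an amide-type nitrogen. Within the data shown here, no measured step touches this amide-type nitrogen aryl, so nothing in the data points to a shift in either direction, and no step beyond the scatter is expected in this assay. Compound 4 is therefore estimated at 150000 nM, with a range from 60000 nM to 350000 nM, which is expected to amount to no change at the digits printed from compound 1 to compound 4 (within the scatter).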

Compound 4, half-maximal cytotoxic concentration: 147000 nM
The estimate for compound 4 lay 1.0-fold (0.01 log units) above the measured number; low and high end bracket the measured number.
By their numbers in this assay, from the lowest: compound 3; then compounds 4, 1 and 2 (each within the scatter of the next).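

Replacing 2-chloro-4-nitrophenyl with 4-methyl-2-nitrophenyl on the amide-type nitrogen gives a 1.0-fold lower number from compound 1 to compound 4 (0.01 log units; within the scatter), the first step read at this position in this assay. For this one pair, the change in the aryl, which loses the chlorine and gains a methyl at the same heavy-atom count, leaves the number unmoved on the shared core of compound 1. No measured data are at hand that could explain this outcome.

Going by these compounds, both aryl groups here carry a nitro group, so it remains open whether an aryl bearing a carboxylic acid or an amine in its place would stay in the same range. Also open, on these data alone, is whether this swap would give the same result with the other aryl group on the core of compound 2 and compound 3.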